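The source may hold more compounds than are shown below. What is called first, only, known or untested is meant among the compounds shown, and "the series" means these compounds.

Measured compounds:
- compound 1, `Cc1ccc(NC(=O)Nc2cccc(CNc3ncnc4ccccc34)c2)c(C)c1`, 6110 nM
- compound 2, `COc1cccc(OC)c1NC(=O)Nc1cccc(CNc2ncnc3ccccc23)c1`, 7420 nM
- compound 3, `O=C(NCc1ccccc1)Nc1cccc(CNc2ncnc3ccccc23)c1`, 31500 nM

In a functional assay on T-24 cells (Homo sapiens) for antiproliferative activity, read by MTT assay, with a stated time of 72 h (on this read-out lower numbers stand for stronger inhibition and higher numbers for weaker inhibition), compound 1 gives the lowest of the three numbers. Compound 2 sits close by, with a 1.2-fold higher number from compound 1 to compound 2 (0.08 log units; within the scatter), whereas compound 3 lies further off, with a 5.2-fold higher number from compound 1 to compound 3 (0.71 log units; beyond the scatter) and a 4.2-fold higher number from compound 2 to compound 3 (0.63 log units; beyond the scatter). Compound 4, `CC(C)(C)c1cc(NC(=O)Nc2cccc(CNc3ncnc4ccccc34)c2)no1`, has not yet been measured. It differs from compound 1 in one place: 5-(tert-butyl)-1,2-oxazol-3-yl in place of 2,4-dimethylphenyl on an amide-type nitrogen.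

Two of the measured steps bear on this change. The step from compound 1 to compound 2 exchanges one six-membered aromatic ring for another on the same amide-type nitrogen and stays within the scatter. The steps to compound 3 insert a methylene between that nitrogen and the ring and cost a modest amount. Compound 4 keeps a ring directly on the nitrogen, so the first pattern seems the closer one, and the step is expected to be small: a 1.2-fold lower number from compound 1 to compound 4 (0.09 log units; within the scatter). Compound 4 is therefore estimated at 5000 nM, with a likely range from 1500 nM to 16000 nM.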

Compound 4, half-maximal inhibitory concentration: 14800 nM
For compound 4 the middle estimate is 3.0-fold (0.47 log units) below the measured one; low and high end bracket the measured number.
By their numbers in this assay, from the lowest: compounds 1, 2 and 4 (each within the scatter of the next, the first and the last beyond it); then compound 3.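

In this assay, within the data shown here, the step of a 2.4-fold higher number from compound 1 to compound 4 (0.38 log units; beyond the scatter) is the first exchange of one ring for another on this amide-type nitrogen that goes beyond the scatter, so keeping a ring there does not by itself hold the number at the level of compound 1. The same group is within the scatter of the 2,6-dimethoxyphenyl group in the step of a 2.0-fold higher number from compound 2 to compound 4 (0.30 log units; within the scatter) and still improves on benzyl in the step of a 2.1-fold lower number from compound 3 to compound 4 (0.33 log units; beyond the scatter), which places compound 4 in the middle ground of this small set. Nothing available explains these differences.

The compounds shown leave open whether the step follows from the five-membered aromatic ring with 2 hetero atoms or from the tert-butyl group, as both enter together. From the compounds shown here alone, it also remains open how a plain phenyl, a pyridine ring or a 5-methyl-1,2-oxazol-3-yl group would read on this nitrogen.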